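Ethyl for Hydrogen on an Amide Series at the Limit

The source may report more compounds than this note shows. Statements on the series, on what has been measured and on what is new or still open speak of the compounds shown alone.

Compound 1 `Cc1ccc(NC(=O)c2cccc(/C=C3\CC(=O)N(c4ccccc4)C3=O)c2)cc1` and compound 2 `O=C(Nc1ccccc1)c1cccc(/C=C2\CC(=O)N(c3ccccc3)C2=O)c1` share one core and differ at a single aromatic carbon. In an ADME assay on HCT-116 cells (Homo sapiens) for cytotoxicity, read by MTT assay, with a stated time of 72 h (on this read-out higher numbers stand for weaker inhibition and lower numbers for stronger inhibition), compound 1 reaches only the assay limit > 100000 nM. In this assay compound 2 likewise gives only the limit > 100000 nM. The step that the two limits leave unreadable from compound 1 to compound 2 is accordingly not readable, since both of its ends rest at the limit of > 100000 nM in this assay, at which 2 of the 2 values shown sit. Compound 3 `CCc1ccc(NC(=O)c2cccc(/C=C3\CC(=O)N(c4ccccc4)C3=O)c2)cc1` carries ethyl in place of hydrogen on an aromatic carbon; cut one bond further out, the same change reads anilino to (4-ethylphenyl)amino. Among the compounds with values here, the only measured step, from compound 1 to compound 2, offers no direction for this change, as its two values both sit at the limit of > 100000 nM in this assay, at which 2 of the 2 values shown sit. In this assay the step of a number no higher from compound 2 to compound 3 (the limit leaves the size open) is therefore expected to be none beyond the scatter. Compound 3 is expected to give an estimate of 100000 nM in this assay, with a range from 30000 nM to 300000 nM, most likely again as a limit.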

Compound 3, half-maximal inhibitory concentration: > 100000 nM
Compound 3: a limit, no number; the forecaster's own chance of this, stated with the estimate: 80%; the middle value lies on the limit itself.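

In this assay compound 3 gives > 100000 nM, which is a limit. No step among compound 1, compound 2 and compound 3 can therefore be read: the limit of > 100000 nM in this assay, at which 3 of the 3 values shown sit.

The compounds shown leave open whether hydrogen, methyl or ethyl on this aromatic carbon makes any difference in this assay.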